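The source may report more compounds than this note shows. Statements on the series, on what has been measured and on what is new or still open speak of the compounds shown alone.

Two compounds share one core and differ only in the group that sits on an amide-type nitrogen. Compound 1 `O=C(CN1CCN(c2cc3c(cc2F)c(=O)c(C(=O)O)cn3C2CC2)CC1)Nc1ccc(Cl)cc1` carries a chloro group on an aromatic carbon of that group. In an ADME assay on WI-38 cells (Homo sapiens) for antiproliferative activity, read by BrdU incorporation, with a stated time of 24 h (on this read-out higher numbers stand for weaker inhibition and lower numbers for stronger inhibition), compound 1 gives only a limit of the assay, > 100000 nM. Compound 2 `COc1ccc(NC(=O)CN2CCN(c3cc4c(cc3F)c(=O)c(C(=O)O)cn4C3CC3)CC2)cc1` carries a methoxy group in place of the chloro group. In this assay compound 2 likewise gives only a limit, > 100000 nM. The step that the two limits leave unreadable from compound 1 to compound 2 therefore cannot be sized, and both measured values stand at the limit of > 100000 nM in this assay, at which 2 of the 2 values shown sit. Compound 3 `COc1cc(NC(=O)CN2CCN(c3cc4c(cc3F)c(=O)c(C(=O)O)cn4C3CC3)CC2)cc(OC)c1OC` is not yet measured; it differs from compound 2 in one place: 3,4,5-trimethoxyphenyl in place of 4-methoxyphenyl on an amide-type nitrogen. Going by the values given here, the only measured step concerns a different exchange and is itself unreadable, so it gives neither a size nor a direction for this assay. With both measured values at the limit, compound 3 is expected to remain at or near that limit as well. Compound 3 is thus estimated at 150000 nM, within a range from 30000 nM to 1000000 nM. This estimate means an expected step that the limit leaves unreadable from compound 2 to compound 3, none beyond the scatter.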

Compound 3, half-maximal inhibitory concentration: > 100000 nM
Compound 3 was reported as a limit; the forecaster's own chance of this, stated with the estimate: 80%; the middle value lies beyond the limit too.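

Compound 3, like compound 1 and compound 2, gives only a limit in this assay, so no step among these three compounds can be read: the limit of > 100000 nM in this assay, at which 3 of the 3 values shown sit.

From the compounds shown here alone, what stays open is whether any group on the amide-type nitrogen of the shared core gives a readable value in this assay, and whether 4-chlorophenyl, 4-methoxyphenyl and 3,4,5-trimethoxyphenyl differ at all.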